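The source may report more compounds than this note shows. Statements on the series, on what has been measured and on what is new or still open speak of the compounds shown alone.

Measured so far in an assay on K177 cells with Neuronal acetylcholine receptor; alpha4/beta2 (Homo sapiens) as the target; a higher number here means a larger maximal response, a lower number a smaller maximal response:

Compound 1, `Cc1ncccc1OC[C@@H]1CCCN1C`: 26.7%
Compound 2, `CN1CCC[C@H]1COc1cccnc1Br`: 12.3%
Compound 3, `CN1CCC[C@H]1COc1cncc(Br)c1`: 41.8%

Compound 3 stands highest of the three, with compound 1 nearest and compound 2 furthest. Compound 1 and compound 2 share a core and differ in one place, (methyl in place of bromo on an aromatic carbon), and the step is a number 14.4 percentage points higher from compound 2 to compound 1 (beyond the scatter). Compound 3 and compound 2 are built from the same atoms joined differently; the difference between the two cores is not broken down here.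

Compound 4, `Cc1cncc(OC[C@@H]2CCCN2C)c1`, is not yet measured. It arises from compound 3 by methyl in place of bromo on an aromatic carbon. This is the same kind of change as that from compound 2 to compound 1, but it sits at another place: in the earlier pair the group is next to the ring nitrogen and ortho to a group of 8 heavy atoms, whereas here it is two atoms from the ring nitrogen and meta to a group of 8 heavy atoms.

The expectation for compound 4 rests on the step from compound 2 to compound 1 being a number 14.4 percentage points higher from compound 2 to compound 1 (beyond the scatter). A step of about a number 12.2 percentage points higher from compound 3 to compound 4 (beyond the scatter) is expected in this assay, somewhat smaller because the starting point of compound 3 is 41.8%. Compound 4 is therefore estimated at 54%, between 36% and 72%.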

Compound 4, largest response reached (reported as maximum), in percent of the reference or control that the assay uses: 77%
Estimate against measurement, compound 4: 23 percentage points below, outside the stated range (above it).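

In this assay, methyl in place of bromo on an aromatic carbon gives a number 35.2 percentage points higher from compound 3 to compound 4 (beyond the scatter), so the change raises the maximal response on both cores, but its size does not carry over unchanged from one core to the other: the same change on two cores in this assay, a number 14.4 percentage points higher (beyond the scatter) from compound 2 to compound 1 and a number 35.2 percentage points higher (beyond the scatter) from compound 3 to compound 4, 20.8 percentage points apart, beyond the scatter of two such steps The direction of the change therefore held in both pairs, while a step read on one core did not give the size of the step on the other. These two pairs do not show why the sizes differ, since the group sits at a different place in each pair, and they support no general rule for the series.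

The compounds shown leave open how a chloro, methoxy or amino group would compare with bromo and methyl at either of these places. They also leave open whether the same change at a third place on this ring would give a step nearer the smaller one or the larger one.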